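Working notes: cytotoxicity outlook for compound 4

The compounds below may be only part of what the source reports. "The series", "measured", "known", "first", "only" and "open" are said of these compounds alone.

Compound 1 `N#Cc1cccc(Cn2ccc3nc(-c4ccccc4)nc-3c2)c1` gives > 100000 nM in an ADME assay on MDBK cells (Bos taurus) for cytotoxicity; on this read-out higher numbers stand for lower toxicity in this test and lower numbers for higher toxicity in this test.
Compound 2 `FC(F)(F)c1cccc(Cn2ccc3nc(-c4ccccc4)nc-3c2)c1` gives 98000 nM in this assay.
Compound 3 `c1ccc(CCCCn2ccc3nc(-c4ccccc4)nc-3c2)cc1` gives 95000 nM in this assay.

The value for compound 1 is a limit of the assay, not a number, as the limit of > 100000 nM in this assay, at which 1 of the 3 values shown sits, shows. Compound 4 `Clc1ccc(Cn2ccc3nc(-c4ccccc4)nc-3c2)s1` is not yet measured; it differs from compound 1 by 5-chlorothiophen-2-yl in place of 3-cyanophenyl on a saturated chain carbon bound to an aromatic nitrogen. For the measured compounds named here, the only measured step is an at least 1.0-fold lower number from compound 1 to compound 2 (0.00 log units; that floor lies within the scatter), a floor that lies within the scatter, and no measured step shares the change from compound 1 to compound 4. All three measured values sit near the top of the range of this assay. Compound 4 is therefore expected to show no step beyond the scatter, a number no higher from compound 1 to compound 4 (the limit leaves the size open). The estimate for compound 4 in this assay is 100000 nM, with a range from 50000 nM to 200000 nM, and a limit again is plausible.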

Compound 4, half-maximal cytotoxic concentration: > 100000 nM
Compound 4 ended at the assay's limit; the forecaster's own chance of this, stated with the estimate: 50%; the middle value sits exactly at the limit.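

In this assay, for the compounds shown here, compound 1 and compound 4 both stand at a limit of the assay, and no step between them can be read. The compounds shown leave open what this assay would give for either compound as a number, and so whether 5-chlorothiophen-2-yl in place of 3-cyanophenyl shifts the read-out at all.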